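The compounds below may be only part of what the source reports. "The series", "measured", "known", "first", "only" and "open" are said of these compounds alone.

Compound 1 `COc1cccc(CNC(=O)c2nc(Br)c3cccnc3c2N[C@H]2CC[C@H](N)CC2)c1` and compound 2 `N[C@H]1CC[C@H](Nc2c(C(=O)NCc3ccc(Cl)cc3)nc(Br)c3cccnc23)CC1` share one core and differ only in the aromatic ring hung from the amide. In a functional assay on SK-BR-3 cells (Homo sapiens) for cytotoxicity, read by MTT assay, with a stated time of 72 h (a lower number here means a stronger inhibitor, a higher number a weaker inhibitor), compound 1 gives 6000 nM and compound 2 gives 2000 nM, a step of a 3.0-fold lower number from compound 1 to compound 2 (0.48 log units; beyond the scatter). Compound 3 `N[C@H]1CC[C@H](Nc2c(C(=O)NCc3ccccn3)nc(Br)c3cccnc23)CC1` carries a pyridin-2-yl ring at that position, but in this assay compound 3 gives "not determined" (no result reported), so no number places it against the other two. Compound 4 `N[C@H]1CC[C@H](Nc2c(C(=O)NCc3ccco3)nc(Br)c3cccnc23)CC1` differs from compound 3 by furan-2-yl in place of pyridin-2-yl on a saturated chain carbon bound to an amide-type nitrogen. For the measured compounds named here, no measured step covers this change; the only comparison of aromatic rings here is the modest one from compound 1 to compound 2. Compound 4 is therefore expected to land near the measured pair, at an estimated 3000 nM with a range of 800 nM to 15000 nM.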

Compound 4, half-maximal inhibitory concentration: 10000 nM
The estimate for compound 4 lay 3.3-fold (0.52 log units) below the measured number; low and high end bracket the measured number.
By their numbers in this assay, from the lowest: compound 2; then compounds 1 and 4 (each within the scatter of the next).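

In this assay, furan-2-yl in place of 4-chlorophenyl gives a 5.0-fold higher number from compound 2 to compound 4 (0.70 log units; beyond the scatter), while furan-2-yl in place of 3-methoxyphenyl gives a 1.7-fold higher number from compound 1 to compound 4 (0.22 log units; within the scatter). Of the three rings with numbers, only the 4-chlorophenyl of compound 2 now stands apart from both others by more than the scatter. No measurement at hand explains this difference. The step from compound 3 to compound 4 cannot be read, and pyridin-2-yl remains unplaced. Also open, as far as these compounds go, is how an amine or a carboxylic acid in place of the ring on this saturated chain carbon would compare.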